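The source may hold more compounds than are shown below. What is called first, only, known or untested is meant among the compounds shown, and "the series" means these compounds.

Measured in a functional assay on MV4-11 cells (Homo sapiens) for inhibition, read by resazurin assay, with a stated time of 72 h; on this read-out higher numbers stand for weaker inhibition of growth and lower numbers for stronger inhibition of growth:
Compound 1 `Cc1ccc(-c2cncc(Cl)c2N2CCC3(CCNC3=O)CC2)o1`: 4950 nM
Compound 2 `CCOCOCc1ccc(-c2cncc(Cl)c2N2CCC3(CCNC3=O)CC2)o1`: 2970 nM
Compound 3 `O=C1NCCC12CCN(c1c(Cl)cncc1-c1ccc(Cl)s1)CC2`: 560 nM

Compound 1, at 4950 nM, sits at the high end of this small set, within the scatter of compound 2, while compound 3 lies clearly lower. The next compound to be tested is compound 4 `CC(=O)c1ccc(-c2cncc(Cl)c2N2CCC3(CCNC3=O)CC2)s1`. It keeps the core of compound 1 but carries 5-acetylthiophen-2-yl in place of 5-methylfuran-2-yl on an aromatic carbon.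

Two measured steps offer some guidance. The first is a 1.7-fold lower number from compound 1 to compound 2 (0.22 log units; within the scatter). It alters the chain on the furan ring and stays within the scatter, so it says little here. The second is an 8.8-fold lower number from compound 1 to compound 3 (0.95 log units; beyond the scatter). It is the closer guide, since it replaces the same 5-methylfuran-2-yl group at the same place, with 5-chlorothiophen-2-yl entering. Going by the values given here, no measured compound carries the acetyl group, however, so compound 3 can only be an approximate guide.

In this assay, among the compounds with values here, a move to a lower number is therefore expected, probably somewhat smaller than the one seen with compound 3. The expected change is a 5.5-fold lower number from compound 1 to compound 4 (0.74 log units; beyond the scatter). For compound 4 the estimated value is 900 nM, within an expected range of 250 nM to 3200 nM.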

Compound 4, concentration for 50% growth inhibition: 1440 nM
Estimate against measurement, compound 4: 1.6-fold (0.20 log units) below, within the range that was stated.
By their numbers in this assay, from the lowest: compound 3; then compound 4; then compounds 2 and 1 (each within the scatter of the next).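

In this assay, 5-acetylthiophen-2-yl, like 5-chlorothiophen-2-yl before it, gives stronger growth inhibition than 5-methylfuran-2-yl on this aromatic carbon of the shared core (a 3.4-fold lower number from compound 1 to compound 4 (0.54 log units; beyond the scatter)), so the gain at this position is not confined to the chloro compound. The group on the ring also counts, not just the ring that carries it: with the rest of the molecule unchanged, acetyl in place of chloro gives weaker inhibition (a 2.6-fold higher number from compound 3 to compound 4 (0.41 log units; beyond the scatter)), leaving compound 3 ahead of compound 4 by a step beyond the usual scatter. Nothing available here accounts for either shift, so the data show the size of these changes but give no reason for them.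

The compounds shown still do not separate the effect of the ring from that of its substituent, since that would take a matched pair such as 5-chlorofuran-2-yl against 5-chlorothiophen-2-yl, or a thiophen-2-yl group with no substituent at all. Going by these compounds, it also remains open how a group of another kind on the ring, such as an amine or a carboxylic acid, would compare with chloro and acetyl.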